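Methoxy removal on the aryl sulfonate series

The source may hold more compounds than are shown below. What is called first, only, known or untested is meant among the compounds shown, and "the series" means these compounds.

Compound 2 `COc1cc(OC)cc(OS(=O)(=O)c2ccc(N3CCN(C)C3=O)cc2)c1` gives 190 nM in a functional assay on HT-29 cells (Homo sapiens) for antiproliferative activity, read by sulforhodamine B assay, with a stated time of 48 h; on this read-out lower numbers stand for stronger inhibition and higher numbers for weaker inhibition. Compound 1 `COc1cccc(OS(=O)(=O)c2ccc(N3CCN(C)C3=O)cc2)c1` gives 2500 nM in this assay, the change hydrogen in place of methoxy on an aromatic carbon having made a 13-fold higher number from compound 2 to compound 1 (1.12 log units; beyond the scatter). Compound 3 `CCN1CCN(c2ccc(S(=O)(=O)Oc3ccc(OC)c(OC)c3)cc2)C1=O` gives 37000 nM in this assay, the highest number of the three. The difference between the cores of compound 2 and compound 3 is not broken down here. Compound 4 `CCN1CCN(c2ccc(S(=O)(=O)Oc3ccc(OC)cc3)cc2)C1=O` is not yet measured. It differs from compound 3 by hydrogen in place of methoxy on an aromatic carbon, the same kind of change as from compound 2 to compound 1, though the place is now ortho to a methoxy group rather than meta to a methoxy group. Beside the earlier 13-fold higher number from compound 2 to compound 1 (1.12 log units; beyond the scatter), a step of a 4.1-fold higher number from compound 3 to compound 4 (0.61 log units; beyond the scatter) is expected here. For the measured compounds named here, that expectation rests on compound 2 going to compound 1 as a 13-fold higher number from compound 2 to compound 1 (1.12 log units; beyond the scatter), the only measured instance. Compound 4 is therefore estimated at 150000 nM in this assay, within 40000 nM to 600000 nM.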

Compound 4, half-maximal inhibitory concentration: 60000 nM
For compound 4 the middle estimate is 2.5-fold (0.40 log units) above the measured one; low and high end bracket the measured number.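

In this assay hydrogen in place of methoxy, ortho to a methoxy group, gives a 1.6-fold higher number from compound 3 to compound 4 (0.21 log units; within the scatter), so on this core the change leaves no difference that stands clear of the scatter. The change does not carry over in size from one core to the other: the same change on two cores in this assay, a 13-fold higher number (1.12 log units; beyond the scatter) from compound 2 to compound 1 and a 1.6-fold higher number (0.21 log units; within the scatter) from compound 3 to compound 4, 8.1-fold (0.91 log units) apart, beyond the scatter of two such steps The two steps differ in core and in place alike, and this gap cannot be assigned to either one.

On these data alone, it remains open whether the same place on both cores would give matching steps. Also open, as far as these compounds go, is how a fluorine, an ethoxy group or an amine would read in place of methoxy on either core.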